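Changing the Aryl Group on a Sulfonyl Sulfur

A few compounds are considered here, and "the series" means these few. Any claim that something is new, unique, unknown or untested is made for them only; others in the source may bear on it.

Compound 1 `Cc1ccccc1S(=O)(=O)Nc1ccc2oc(-c3ccccc3)nc2c1` is one of three compounds tested in an ADME assay on HEK293 cells (Homo sapiens) for cytotoxicity, read by resazurin assay, with a stated time of 48 h (on this read-out higher numbers stand for lower toxicity in this test and lower numbers for higher toxicity in this test), where compound 1 gives 57000 nM. Compound 3 `CCc1ccc(S(=O)(=O)Nc2ccc(-c3nc4ccccc4o3)cc2)cc1` gives 82000 nM in this assay, and the gap between compound 1 and compound 3 lies within the usual scatter of this kind of measurement. Compound 2 `O=S(=O)(Nc1ccc(-c2nc3ccccc3o2)cc1)c1ccccc1O` is reported only as a limit in this assay, namely > 100000 nM; the limit is the limit of > 100000 nM in this assay, at which 1 of the 3 values shown sits. Compound 1 thus has the lowest of the two plain numbers, without standing apart from compound 3.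

Compound 4 `O=S(=O)(Nc1ccc2oc(-c3ccccc3)nc2c1)c1ccc(Cl)c(Cl)c1` has not been measured. It differs from compound 1 in one place: 3,4-dichlorophenyl in place of 2-methylphenyl on a sulfonyl sulfur. Within the data shown here, the only measured step that also exchanges the aryl group on the sulfonyl sulfur is an at least 1.2-fold lower number from compound 2 to compound 3 (0.08 log units; that floor lies within the scatter), which stays within the scatter. On that basis no step beyond the scatter is expected here, and the expected change is a 1.1-fold lower number from compound 1 to compound 4 (0.06 log units; within the scatter). Compound 4 is therefore estimated at 50000 nM in this assay, with a likely range from 20000 nM to 100000 nM.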

Compound 4, half-maximal cytotoxic concentration: 71000 nM
Compound 4: middle estimate off by 1.4-fold (0.15 log units), on the low side; low and high end bracket the measured number.
By their numbers in this assay, from the lowest: compounds 1, 4 and 3 (each within the scatter of the next). At a limit, above all of these: compound 2.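

In this assay, 3,4-dichlorophenyl in place of 2-methylphenyl on a sulfonyl sulfur gives a 1.2-fold higher number from compound 1 to compound 4 (0.10 log units; within the scatter). This step has a plain number at both ends, and it shows that on the core of compound 1 this position can carry an aryl group with two chlorine atoms without a change beyond the scatter. The earlier step at this position rests on compound 2, which is reported only as a limit: the limit of > 100000 nM in this assay, at which 1 of the 4 values shown sits.

All the compounds shown carry an aryl group on the sulfonyl sulfur, so it remains open how a cyclohexyl group, a longer alkyl chain, or an aryl group bearing an amine or a carboxylic acid would read in this assay. From the compounds shown here alone, it also remains open how a phenyl group with a single chlorine would compare on this core.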